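Swapping the Amide Substituent: Fluorophenyl to Methylbenzyl

This account rests on a few compounds, and the source may have more. Where it says the series, first, only, none or still open, it means among the compounds named here.

Measured so far in a functional assay on HCT-116 cells (Homo sapiens) for antiproliferative activity, read by MTT assay, with a stated time of 48 h; on this read-out lower numbers stand for stronger inhibition and higher numbers for weaker inhibition:
Compound 1, `COc1cc(-c2nnc(SCC(=O)c3cccc(Br)c3)n2N)cc(OC)c1OC`, gives 5320 nM.
Compound 2, `COc1cc(-c2nnc(SCC(=O)Nc3ccccc3C)n2N)cc(OC)c1OC`, gives only a limit, > 100000 nM.
Compound 3, `COc1cc(-c2nnc(SCC(=O)Nc3ccccc3F)n2N)cc(OC)c1OC`, gives 1160 nM.

Compound 3 holds the lowest of the two real numbers; compound 1 sits higher, as a 4.6-fold lower number from compound 1 to compound 3 (0.66 log units; beyond the scatter) shows, and compound 2 stopped at the limit of > 100000 nM in this assay, at which 1 of the 3 values shown sits. Compound 4, `COc1cc(-c2nnc(SCC(=O)NCc3ccc(C)cc3)n2N)cc(OC)c1OC`, differs from compound 3 by 4-methylbenzyl in place of 2-fluorophenyl on an amide-type nitrogen. The step that bears most on this is an at least 86-fold lower number from compound 2 to compound 3 (1.93 log units; beyond the scatter), where a methyl group replacing fluoro coincided with a large loss. Among the measured compounds shown here, compound 4 carries a methyl group again, though on a 4-methylbenzyl rather than a 2-methylphenyl, and no measured step covers the benzyl itself. A higher number is therefore expected, a 7.8-fold higher number from compound 3 to compound 4 (0.89 log units; beyond the scatter). Compound 4 is estimated at 9000 nM, between 1500 nM and 60000 nM.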

Compound 4, half-maximal inhibitory concentration: > 100000 nM
Compound 4 gave a limit, no number; the forecaster's own chance of this, stated with the estimate: 25%; at least 11-fold (1.04 log units) between middle value and limit.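

Compound 4 gives a limit, not a number, and compound 2 gives the same limit: the limit of > 100000 nM in this assay, at which 2 of the 4 values shown sit. On this amide-type nitrogen, 4-methylbenzyl cannot replace 2-fluorophenyl without a large loss, an at least 86-fold higher number from compound 3 to compound 4 (1.93 log units; beyond the scatter), and (4-methylbenzyl)amino on the carbonyl carbon also falls short of 3-bromophenyl, an at least 18-fold higher number from compound 1 to compound 4 (1.27 log units; beyond the scatter). The step joining the two limits cannot be read, but both compounds with a methyl-bearing ring now sit at the limit. As far as these compounds go, it stays open whether the loss goes with the methyl group or with the benzyl link; a plain benzyl or a 4-fluorobenzyl on this nitrogen would separate the two.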